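The source may hold more compounds than are shown below. What is called first, only, known or untested is meant among the compounds shown, and "the series" means these compounds.

Measured compounds:
Compound 1 `Cc1ccnc(-c2ccccc2OCC2=NCCN2)c1` in a functional assay for activation of Alpha-1B adrenergic receptor (Homo sapiens), read by calcium flux (a higher number here means that more compound is needed for the effect, a lower number that less compound is needed), reports only a limit, < 100000 nM.
Compound 2 `c1ccc(-c2cnccn2)c(OCC2=NCCN2)c1` gives 631 nM in this assay.
Compound 3 `c1ccc(-c2ccoc2)c(OCC2=NCCN2)c1` gives 5.01 nM in this assay.

Among the two numbers reported, compound 3 has the lowest. Going by the values given here, the single measured step is a 130-fold lower number from compound 2 to compound 3 (2.10 log units; beyond the scatter), a large gain when a five-membered ring with one hetero atom replaced a six-membered ring with two. Compound 4 `Cc1ccc(-c2ccccc2OCC2=NCCN2)s1` is reached from compound 3 by 5-methylthiophen-2-yl in place of furan-3-yl on an aromatic carbon. That measured step bears only loosely here, since both rings in the new pair are five-membered with a single hetero atom. In this assay compound 4 is expected to show a step of a 2.0-fold higher number from compound 3 to compound 4 (0.30 log units; within the scatter), within or near the scatter. Compound 4 is estimated at 10 nM, with a likely range from 2 nM to 60 nM.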

Compound 4, half-maximal effective concentration: < 100000 nM
Compound 4: a limit, no number; the forecaster's own chance of this, stated with the estimate: 3%; the middle value does not contradict the limit.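

Going by these compounds alone, compound 4 gives < 100000 nM in this assay which is a limit and not a number, so no step from compound 2 or compound 3 to compound 4 can be read. The compounds shown leave open how 5-methylthiophen-2-yl truly compares with furan-3-yl.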